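Acetyl in Place of Hydrogen on the Ring Nitrogen of Compound 2

The compounds below may be only part of what the source reports. "The series", "measured", "known", "first", "only" and "open" are said of these compounds alone.

Measured so far:
compound 1, `COc1ccc(-c2c[nH]c(=O)n2-c2cc(OC)c(OC)c(OC)c2)cc1OC`: "not determined" (no result reported)
compound 2, `COc1ccc(-c2c[nH]c(=O)n2-c2cc(OC)c(OC)c(OC)c2)cc1N`: > 50000 nM
compound 3, `COc1ccc(-c2cn(C(=O)Nc3cc(OC)c(OC)c(OC)c3)c(=O)n2-c2cc(OC)c(OC)c(OC)c2)cc1N`: > 50000 nM

In a functional assay on MCF7 cells (Homo sapiens) for cytotoxicity, read by MTT assay, with a stated time of 48 h (a higher number here means a weaker inhibitor, a lower number a stronger inhibitor), compound 2 gives > 50000 nM, which is a limit of the assay and not a number. Compound 3 also reaches only a limit, > 50000 nM. For compound 1 no result is given in this assay: "not determined" (no result reported). Compound 2 therefore stands at the limit of > 50000 nM in this assay, at which 2 of the 3 values shown sit, with nothing weaker or stronger around it to compare.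

Compound 4, `COc1ccc(-c2cn(C(C)=O)c(=O)n2-c2cc(OC)c(OC)c(OC)c2)cc1N`, differs from compound 2 in one place: acetyl in place of hydrogen on an aromatic nitrogen. Among the compounds with values here, no measured step exists to gauge such a change. With both numbered results sitting at the limit, the expected step of a number no higher from compound 2 to compound 4 (the limit leaves the size open) is none beyond the scatter. Compound 4 is estimated to give 50000 nM, within 20000 nM to 120000 nM, most probably again reported only as a limit.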

Compound 4, half-maximal inhibitory concentration: 43400 nM
For compound 4 the middle estimate is 1.2-fold (0.06 log units) above the measured one, and the stated range covers the measured number.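

In this assay compound 4 gives 43400 nM as the only actual number among the compounds shown. Acetyl on this aromatic nitrogen gives an at least 1.1-fold lower number from compound 2 to compound 4 (0.06 log units; that floor lies within the scatter) so no real change can be claimed from this step. Compound 2 has only a limit and not a number, which leaves the true size of the step open: the limit of > 50000 nM in this assay, at which 2 of the 4 values shown sit.

On these data alone, whether a methyl or a benzoyl group on the same nitrogen would give a clearly different number remains open. The compounds shown also leave open whether any group here can bring a strong effect on these cells.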